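This account rests on a few compounds, and the source may have more. Where it says the series, first, only, none or still open, it means among the compounds named here.

Compound 1 `C[C@@H](Oc1cc2oc(=O)n(CCC(=O)O)c2cc1Cl)c1ccc(F)cn1`: in a physicochemical assay for permeability, using PAMPA (a higher number here means that the compound crosses the layer faster, a lower number that the compound crosses the layer more slowly), compound 1 gives 31 nm/s.
Compound 2 `CCOc1cc2oc(=O)n(CCC(=O)O)c2cc1Cl`: in this assay compound 2 gives only a limit, < 10 nm/s.
Compound 3 `C[C@@H](Oc1cc2oc(=O)n(CCC(=O)O)c2cc1Cl)c1cccnn1`: in this assay compound 3 gives only a limit, < 3 nm/s.

Compound 3 stands lowest of the three, at a limit rather than a number, (the limit of < 3 nm/s in this assay, at which 1 of the 3 values shown sits). Compound 2 likewise rests at a limit, (the limit of < 10 nm/s in this assay, at which 1 of the 3 values shown sits). Compound 4 `Cc1cccc([C@@H](C)Oc2cc3oc(=O)n(CCC(=O)O)c3cc2Cl)n1` differs from compound 3 in one place: 6-methylpyridin-2-yl in place of pyridazin-3-yl on a saturated chain carbon bound to an oxygen on an aromatic ring and a saturated chain carbon. The step that bears on this is an at least 10-fold lower number from compound 1 to compound 3 (1.01 log units; beyond the scatter), where compound 1 carries 5-fluoropyridin-2-yl at the same carbon; compound 4 returns to a pyridin-2-yl ring, so a large rise is expected when that step is read in reverse. Compound 4 is therefore estimated at 30 nm/s, between 10 nm/s and 90 nm/s, an expected step of an at least 10-fold higher number from compound 3 to compound 4 (1.00 log units; beyond the scatter).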

Compound 4, apparent permeability: 21 nm/s
Estimate against measurement, compound 4: 1.4-fold (0.15 log units) above; measured number inside the range.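

In this assay, a second ring other than pyridazin-3-yl need not carry the fluorine to restore crossing: 6-methylpyridin-2-yl gives an at least 7.0-fold higher number from compound 3 to compound 4 (0.84 log units; beyond the scatter) and an at least 2.1-fold higher number from compound 2 to compound 4 (0.32 log units; beyond the scatter). Exchanging 5-fluoropyridin-2-yl for 6-methylpyridin-2-yl gives a 1.5-fold lower number from compound 1 to compound 4 (0.17 log units; within the scatter), so two differently substituted pyridin-2-yl groups now read alike at this carbon. Both steps that start from a limit leave their full size open. Also open, going by these compounds, is what a plain phenyl ring or an amine-bearing group at this carbon would give.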